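Swapping the hydrazone aryl group: a step to compound 3

The compounds below may be only part of what the source reports. "The series", "measured", "known", "first", "only" and "open" are said of these compounds alone.

Compound 1 `CN(C)CCn1cnnc1-c1cc(Oc2ccc(NC(=O)N/N=C/c3cc(C(C)(C)C)cc(C(C)(C)C)c3O)cc2F)ccn1`: in a functional assay on MKN-45 cells (Homo sapiens) for cytotoxicity, read by MTT assay, with a stated time of 72 h (on this read-out higher numbers stand for weaker inhibition and lower numbers for stronger inhibition), compound 1 gives 3300 nM.
Compound 2 `CN(C)CCn1cnnc1-c1cc(Oc2ccc(NC(=O)N/N=C/c3ccccc3O[N+](=O)[O-])cc2F)ccn1`: in this assay compound 2 gives 1020 nM.

Among the measured compounds shown here, only two compounds have numbers so far, and compound 2 holds the lower of the two. Its gap to compound 1 is beyond the usual scatter, so compound 2 is the stronger inhibitor of this pair on the read-out of this assay.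

Compound 3 `CN(C)CCn1cnnc1-c1cc(Oc2ccc(NC(=O)N/N=C/c3cccc(Br)c3)cc2F)ccn1` is not yet measured. It keeps the shared core and differs from compound 2 in one place: 3-bromophenyl in place of 2-(nitrooxy)phenyl on a carbon with a double bond to nitrogen. For the measured compounds named here, no step between measured compounds touches this part of the molecule, so nothing measured here shows how such a swap plays out. The expectation for this assay therefore rests on compound 2 alone, with no clear direction to lean on; a step of small size is expected, which may well fall within the scatter, with a slight lean toward a higher number as the step of a 1.5-fold higher number from compound 2 to compound 3 (0.17 log units; within the scatter) expresses. Compound 3 is expected to give about 1500 nM, within a range from 500 nM to 5000 nM.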

Compound 3, half-maximal inhibitory concentration: 450 nM
Compound 3: middle estimate off by 3.3-fold (0.52 log units), on the high side, outside the stated range (below it).
By their numbers in this assay, from the lowest: compound 3; then compound 2; then compound 1.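

Among the compounds shown here, until now no step had touched the aryl group on the carbon with a double bond to nitrogen, and this exchange gives the first reading there: in this assay, 3-bromophenyl in place of 2-(nitrooxy)phenyl brings a 2.3-fold lower number from compound 2 to compound 3 (0.36 log units; beyond the scatter), a modest change but one beyond the scatter. The place therefore responds to what it carries, and the entering group, with fewer heavy atoms, a bromine and no hydrogen-bond acceptors, leaves compound 3 with the lowest number of the three compounds. No measurement shown here bears on why the number moved, and the single step changes several things at once, so it cannot assign the shift to any one of them.

Still open, as far as these compounds go, is whether the lower number follows the bromine itself or its place in 3-bromophenyl, and where an unsubstituted phenyl, a 3-chlorophenyl or a 3-methoxyphenyl would stand on the same carbon. From the compounds shown here alone, it is equally open whether a step of this size would carry over if the shared core bore a longer chain in place of its dimethylaminoethyl group.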